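This account rests on a few compounds, and the source may have more. Where it says the series, first, only, none or still open, it means among the compounds named here.

Among the compounds with values here, compound 2 `Cc1ccc(-c2cc(/C=C/c3ccc(C(=O)NO)cc3)ccn2)c(F)c1` is one of two compounds measured so far in an assay on isolated protein for inhibition of protein deacetylase HDAC6 (Homo sapiens), read by fluorescence, with a stated time of 15 min; on this read-out lower numbers stand for stronger inhibition and higher numbers for weaker inhibition. In this assay compound 2 gives 15 nM, the higher of the two numbers, while compound 1 `O=C(NO)c1ccc(/C=C/c2ccnc(-c3cccnc3)c2)cc1` gives 14 nM; the difference between them, a 1.1-fold higher number from compound 1 to compound 2 (0.03 log units; within the scatter), came from exchanging the group on the same aromatic carbon of the shared core that is varied again here. Compound 3 `O=C(NO)c1ccc(/C=C/c2ccnc(-c3ccsc3)c2)cc1` is not yet measured. It differs from compound 2 in one place: thiophen-3-yl in place of 2-fluoro-4-methylphenyl on an aromatic carbon. Within the data shown here, the only measured step that bears on this position is the one from compound 1 to compound 2, which stayed within the scatter, so a change at this aromatic carbon has so far left the number unchanged. For compound 3 the expected step is therefore a 1.1-fold lower number from compound 2 to compound 3 (0.03 log units; within the scatter), none beyond the scatter. Compound 3 is estimated at 14 nM, within a range of 6 nM to 35 nM.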

Compound 3, half-maximal inhibitory concentration: 54 nM
Estimate against measurement, compound 3: 3.9-fold (0.59 log units) below, and the stated range ends below it.
By their numbers in this assay, from the lowest: compounds 1 and 2 (each within the scatter of the next); then compound 3.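

Exchanging 2-fluoro-4-methylphenyl for thiophen-3-yl brings a 3.6-fold higher number from compound 2 to compound 3 (0.56 log units; beyond the scatter) and exchanging pyridin-3-yl for it brings a 3.9-fold higher number from compound 1 to compound 3 (0.59 log units; beyond the scatter) in this assay and so shows that the group on this carbon, next to the ring nitrogen, can move the number beyond the scatter, if only modestly. Within the data shown here, the earlier agreement therefore holds only between the two six-membered aromatic groups, and thiophen-3-yl is the one group here that departs from them. This exchange changes ring size, hetero atom and heavy-atom count together, and the three compounds do not separate these changes. Nothing given here explains the step. Going by these compounds, whether sulfur or ring size sets the number remains open, and furan-3-yl would bear on that. Also open, on these data alone, is how this carbon would respond to a non-aromatic group such as an amine or a longer chain.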